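The compounds below may be only part of what the source reports. "The series", "measured", "known", "first", "only" and "open" are said of these compounds alone.

Measured compounds:
compound 1 `CCOC(=O)c1cc(=O)c2cc(CSC(=S)N(C)c3ccccc3)ccc2o1` — 18100 nM
compound 2 `COc1ccc2oc(CSC(=S)N3CCCCC3)cc(=O)c2c1` — 11900 nM

Compound 1 `CCOC(=O)c1cc(=O)c2cc(CSC(=S)N(C)c3ccccc3)ccc2o1` gives 18100 nM in a functional assay on HeLa cells (Homo sapiens) for antiproliferative activity, read by MTT assay, with a stated time of 72 h; a lower number here means a stronger inhibitor, a higher number a weaker inhibitor. Compound 2 `COc1ccc2oc(CSC(=S)N3CCCCC3)cc(=O)c2c1`, which carries a different core, gives 11900 nM in this assay. Of the two numbers, that of compound 1 is the higher, but compound 2 lies within the scatter of it, so the two compounds are not told apart by this assay.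

Compound 3 `CCOC(=O)c1cc(=O)c2cc(CSC(=S)N3CCCCC3)ccc2o1` keeps the core of compound 1 and differs from it only at the thiocarbonyl carbon: piperidin-1-yl in place of methyl(phenyl)amino on a thiocarbonyl carbon. Among the measured compounds shown here, no measured pair isolates this change on a shared core. For the measured compounds named here, the only guide is that compound 2 already carries piperidin-1-yl on its own core and shows no difference from compound 1 beyond the scatter. The expected step from compound 1 to compound 3 in this assay is therefore a 1.3-fold lower number from compound 1 to compound 3 (0.11 log units; within the scatter), which is not expected to exceed the scatter in either direction. Compound 3 is estimated to give 14000 nM in this assay, with a likely range from 5000 nM to 40000 nM.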

Compound 3, half-maximal inhibitory concentration: 5800 nM
Estimate against measurement, compound 3: 2.4-fold (0.38 log units) above; the range from low to high includes it.
By their numbers in this assay, from the lowest: compound 3; then compounds 2 and 1 (each within the scatter of the next).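

On the core of compound 1, the group on a thiocarbonyl carbon whose other neighbours are sulfur proves to count in this assay: piperidin-1-yl in place of methyl(phenyl)amino gives a 3.1-fold lower number from compound 1 to compound 3 (0.49 log units; beyond the scatter), a modest step but one beyond the scatter. The earlier pair could not show this, as compound 1 and compound 2 differ in more than one place and their numbers lie within the scatter of each other; here a single exchange at this position separates two compounds on a shared core. The data shown offer no explanation for the size or direction of this step.

The compounds shown leave open whether the same exchange would have a similar effect on the core of compound 2, which appears here only with piperidin-1-yl. They also leave open how other amines on the thiocarbonyl carbon, such as morpholin-4-yl, pyrrolidin-1-yl or open-chain diethylamino, would stand against piperidin-1-yl in this assay.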